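The source may report more compounds than this note shows. Statements on the series, on what has been measured and on what is new or still open speak of the compounds shown alone.

Measured so far:
- Compound 1, `CCOC(=O)[C@H](CCC(=O)O)NC(=O)c1ccc(CNc2nc3cc(N)cc(N)c3nc2-c2ccccc2)cc1`: < 100000 nM
- Compound 2, `Nc1cc(N)c2nc(-c3ccccc3)c(NCc3ccc(Cl)c(Cl)c3)nc2c1`: 12900 nM
- Compound 3, `CCOC(=O)[C@H](CCC(=O)O)NC(=O)c1ccc(Oc2nc3cc(N)cc(N)c3nc2-c2ccccc2)cc1`: 6310 nM

All three compounds share one core and were tested in a functional assay on TK-10 cells (Homo sapiens) for inhibition, read by sulforhodamine B assay, with a stated time of 48 h; a lower number here means a stronger inhibitor of growth, a higher number a weaker inhibitor of growth. For compound 1 the result is only a limit of the assay, < 100000 nM, so it does not give a number that can be ranked. Among the two numbers that are known, compound 2 stands highest, with 12900 nM. Its nearest neighbour is compound 3, whose 6310 nM lies a step apart that is beyond the usual scatter, so the two compounds do differ in this assay.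

The next compound, compound 4, `Nc1cc(N)c2nc(-c3ccccc3)c(NCc3ccc(F)cc3)nc2c1`, is not yet measured. It differs from compound 2 in one place: 4-fluorophenyl in place of 3,4-dichlorophenyl on a saturated chain carbon bound to a nitrogen on an aromatic ring. Within the data shown here, no measured pair shows the size of such a change here. The step of a 1.9-fold higher number from compound 2 to compound 4 (0.29 log units; within the scatter) is therefore an expectation rather than a reading, and it is expected to point toward a weaker inhibitor. For compound 4 the estimated value in this assay is 25000 nM, with a likely range from 8000 nM to 80000 nM.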

Compound 4, concentration for 50% growth inhibition: 5890 nM
For compound 4 the middle estimate is 4.2-fold (0.63 log units) above the measured one; measured number below the stated range.
By their numbers in this assay, from the lowest: compounds 4 and 3 (each within the scatter of the next); then compound 2.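

Among these compounds, compounds 2 and 4 are the first pair here that differ in only one place, so they give the first direct reading of this position. In this assay, 4-fluorophenyl in place of 3,4-dichlorophenyl on a saturated chain carbon bound to a nitrogen on an aromatic ring gives a 2.2-fold lower number from compound 2 to compound 4 (0.34 log units; beyond the scatter). The change is modest, but it shows that this position affects growth inhibition and that the two chlorines are not required, since the fluorinated compound is the stronger inhibitor.

On these data alone, whether the gain follows the fluorine, the loss of the chlorines or something else stays open, and a 4-chlorophenyl or a 4-methoxyphenyl at this place would help separate these possibilities. Nothing among the measurements shown explains the size or direction of this step.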